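A few compounds are considered here, and "the series" means these few. Any claim that something is new, unique, unknown or untested is made for them only; others in the source may bear on it.

Compound 1 `Cc1ccccc1-c1nnc(N(C)N)s1` and compound 2 `CNNc1nnc(-c2ccccc2C)s1` share one core and differ only in how a methyl group and an amino group are arranged on the nitrogen attached to the aromatic carbon. In a functional assay on the whole organism with Mus musculus as the target, in the maximal electroshock model, with a stated time of 1 h (on this read-out lower numbers stand for an effect already at smaller amounts and higher numbers for an effect only at larger amounts of compound), compound 1 gives 75 mg/kg. For compound 2 this assay reports only a limit, > 100 mg/kg, not a number. The step of an at least 1.3-fold higher number from compound 1 to compound 2 (0.12 log units; that floor lies within the scatter) can therefore be sized only by its floor, and compound 2 stands at the boundary of the values shown, the limit (the limit of > 100 mg/kg in this assay, at which 1 of the 2 values shown sits).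

Compound 3 `Cc1ccccc1-c1nnc(NNC(C)C)s1` is the next change: isopropyl in place of methyl on an amine nitrogen. Among the measured compounds shown here, no measured step varies the size of this alkyl group; the single step available moves the methyl between two nitrogens and does not bear directly on exchanging methyl for isopropyl. With nothing pointing either way, the expected step that the limit leaves unreadable from compound 2 to compound 3 means no shift beyond the scatter. Compound 3 is thus estimated at 150 mg/kg, with a range from 70 mg/kg to 400 mg/kg, and there is a fair chance this assay again returns only a limit for it.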

Compound 3, dose for half-maximal effect: 83 mg/kg
The estimate for compound 3 lay 1.8-fold (0.26 log units) above the measured number; the measured number falls inside the stated range.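

In this assay, isopropyl on this amine nitrogen yields a measured number, whereas the methyl group of compound 2 yielded only a limit. The change reads as an at least 1.2-fold lower number from compound 2 to compound 3 (0.08 log units; that floor lies within the scatter), a size that is only a floor, because the starting point of the step is a limit: the limit of > 100 mg/kg in this assay, at which 1 of the 3 values shown sits. The comparison with compound 1, where the methyl and amino groups sit differently on the nitrogen attached to the aromatic carbon, gives a fully readable step, a 1.1-fold higher number from compound 1 to compound 3 (0.04 log units; within the scatter), so this assay offers no ground for ranking these two compounds.

As far as these compounds go, with only methyl and isopropyl on this nitrogen, no trend with the alkyl group can be drawn, and it remains open how an ethyl group, a longer chain such as butyl, or a cyclohexyl ring would read in this assay. The true distance between compound 2 and compound 3 also stays unsettled, as does the effect of replacing the methyl group on the aromatic ring of the shared core with a chlorine atom or a methoxy group.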